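Benzyl Groups on the Ring Nitrogen of a Shared Core

A few compounds are considered here, and "the series" means these few. Any claim that something is new, unique, unknown or untested is made for them only; others in the source may bear on it.

Compound 1 `COc1ccc(-c2ccc3c(c2)C(=O)C(=O)N3)cc1` carries only a hydrogen on the amide-type nitrogen in a ring of its core. In a functional assay on K562 cells (Homo sapiens) for antiproliferative activity, read by MTT assay, with a stated time of 48 h (on this read-out higher numbers stand for weaker inhibition and lower numbers for stronger inhibition), compound 1 gives 6920 nM, the highest of the three measured numbers. Compound 2 `COc1ccc(-c2ccc3c(c2)C(=O)C(=O)N3Cc2ccc(Br)cc2)cc1` gives 100 nM and compound 3 `COc1ccc(-c2ccc3c(c2)C(=O)C(=O)N3Cc2cc(C)cc(C)c2)cc1` gives 140 nM. Both steps are large: a 69-fold lower number from compound 1 to compound 2 (1.84 log units; beyond the scatter) and a 49-fold lower number from compound 1 to compound 3 (1.69 log units; beyond the scatter), whereas a 1.4-fold higher number from compound 2 to compound 3 (0.15 log units; within the scatter) lies within the scatter. Compound 4 `COc1ccc(-c2ccc3c(c2)C(=O)C(=O)N3Cc2ccc(C#N)cc2)cc1` differs from compound 1 by 4-cyanobenzyl in place of hydrogen on an amide-type nitrogen in a ring. Those two earlier steps, each placing a substituted benzyl on that same nitrogen, bear directly on this change, and a step of comparable size is expected. The expected step is a 53-fold lower number from compound 1 to compound 4 (1.73 log units; beyond the scatter), a large decrease in this assay. The estimate for compound 4 is 130 nM, within 50 nM to 400 nM.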

Compound 4, half-maximal inhibitory concentration: 380 nM
For compound 4 the middle estimate is 2.9-fold (0.47 log units) below the measured one; measured number inside the range.
By their numbers in this assay, from the lowest: compounds 2 and 3 (each within the scatter of the next); then compound 4; then compound 1.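

In this assay, the gain from a substituted benzyl on the amide-type nitrogen in a ring holds for 4-cyanobenzyl too, with an 18-fold lower number from compound 1 to compound 4 (1.26 log units; beyond the scatter). The earlier benzyl groups could not be told apart, but the substituent now matters, with a 3.8-fold higher number from compound 2 to compound 4 (0.58 log units; beyond the scatter) and a 2.7-fold higher number from compound 3 to compound 4 (0.43 log units; beyond the scatter). Nothing available here accounts for this difference. Going by these compounds, whether an amine or a carboxylic acid in place of cyano on the aromatic carbon would keep such low numbers stays open. So does the outcome of a longer chain in place of the benzyl group on that nitrogen.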